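Clearance notes on a hydroxyethoxy variant of compound 2

The compounds below may be only part of what the source reports. "The series", "measured", "known", "first", "only" and "open" are said of these compounds alone.

Measured so far in an ADME assay on the whole organism (Rattus norvegicus) for pharmacokinetics; on this read-out lower numbers stand for slow clearance and higher numbers for fast clearance:
- compound 1 `CCC(CC)C1C(C(=O)c2ccc(OC)cc2)=C(O)C(=O)N1c1ccc(-c2ccon2)cc1`: 5.1 mL/min/kg
- compound 2 `COc1ccc(C(=O)C2=C(O)C(=O)N(c3ccc(-c4ccon4)cc3)C2c2ccccc2OC)cc1`: 8.8 mL/min/kg
- compound 3 `COc1ccccc1C1C(C(=O)C(C)(C)C)=C(O)C(=O)N1c1ccc(-c2ccon2)cc1`: 1.3 mL/min/kg

In this assay compound 2 gives the highest of the three numbers. Its nearest neighbour is compound 1, where a 1.7-fold higher number from compound 1 to compound 2 (0.24 log units; within the scatter) falls within the scatter; the furthest is compound 3, where a 6.8-fold lower number from compound 2 to compound 3 (0.83 log units; beyond the scatter) lies beyond the scatter and counts as modest.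

Compound 4 `COc1ccc(C(=O)C2=C(O)C(=O)N(c3ccc(-c4ccon4)cc3)C2c2ccccc2OCCO)cc1` is not yet measured. Against compound 2 the change is hydroxymethyl in place of hydrogen on a saturated chain carbon bound to an oxygen on an aromatic ring.

Neither measured step touches this place. For the measured compounds named here, the step from compound 1 to compound 2 exchanges the group on the saturated ring carbon and stays within the scatter; the step from compound 2 to compound 3 exchanges the group on the carbonyl carbon and is the only step beyond the scatter. Going by the values given here, nothing measured shows what a small polar addition on the chain bound to the aromatic oxygen does, so the series offers no direction for this step.

For compound 4 the expected step in this assay is a 1.1-fold lower number from compound 2 to compound 4 (0.04 log units; within the scatter), which is taken to sit within the scatter. Compound 4 is therefore estimated at 8 mL/min/kg in this assay, with a range from 3.5 mL/min/kg to 18 mL/min/kg.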

Compound 4, clearance in the Rattus norvegicus assay: 67.6 mL/min/kg
Estimate against measurement, compound 4: 8.5-fold (0.93 log units) below, outside the stated range (above it).
By their numbers in the Rattus norvegicus assay, from the lowest: compound 3; then compounds 1 and 2 (each within the scatter of the next); then compound 4.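

The position on the chain bound to the aromatic oxygen is not silent in the Rattus norvegicus assay, where compound 2 gives 8.8 mL/min/kg, compound 3 gives 1.3 mL/min/kg and compound 4 gives 67.6 mL/min/kg: hydroxymethyl in place of hydrogen there gives a 7.7-fold higher number from compound 2 to compound 4 (0.89 log units; beyond the scatter), a step beyond the scatter and opposite in direction to the exchange on the carbonyl carbon, a 6.8-fold lower number from compound 2 to compound 3 (0.83 log units; beyond the scatter). Exchanges on the saturated ring carbon now read differently too: 2-(2-hydroxyethoxy)phenyl in place of pentan-3-yl gives a 13-fold higher number from compound 1 to compound 4 (1.12 log units; beyond the scatter), whereas 2-methoxyphenyl at that place gave a 1.7-fold higher number from compound 1 to compound 2 (0.24 log units; within the scatter), so the added hydroxymethyl separates the two outcomes. In a physicochemical assay for solubility, in phosphate buffer, at pH 6.8 (on this read-out higher numbers stand for higher solubility and lower numbers for lower solubility), compound 2 gives 34700 nM. In the physicochemical assay compound 4 gives > 50000 nM, which is a limit of the assay and not a number. In the physicochemical assay the step of an at least 1.4-fold higher number from compound 2 to compound 4 (0.15 log units; that floor lies within the scatter) is only a floor set by that limit, so its real size stays unread: the limit of > 50000 nM in the physicochemical assay, at which 1 of the 2 values shown sits.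

Open is whether the rise in clearance follows the hydroxyl itself or the longer chain, since the compounds shown hold no ethoxy or 2-methoxyethoxy group at this place, and no amine or carboxylic acid on the chain. Also open, going by these compounds, is whether 2-(2-hydroxyethoxy)phenyl gives a similar step on the tert-butyl carbonyl of compound 3.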